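The source may report more compounds than this note shows. Statements on the series, on what has been measured and on what is new or still open speak of the compounds shown alone.

Compound 1 `O=C1C(=Cc2ccc(O)cc2)C(=O)N(c2ccc(Cl)cc2)N1c1ccc(Cl)cc1` carries the shared core with a 4-hydroxyphenyl group. In a functional assay on ECa-109 cells (Homo sapiens) for cytotoxicity, read by MTT assay, with a stated time of 72 h (a higher number here means a weaker inhibitor, a lower number a stronger inhibitor), compound 1 gives 34200 nM, the second highest of the three numbers; compound 2 `O=C1C(=Cc2ccc(F)cc2)C(=O)N(c2ccc(Cl)cc2)N1c1ccc(Cl)cc1` gives 35600 nM, and compound 3 `O=C1C(=Cc2ccc(Br)cc2)C(=O)N(c2ccc(Cl)cc2)N1c1ccc(Cl)cc1` gives 12300 nM. The step of a 1.0-fold higher number from compound 1 to compound 2 (0.02 log units; within the scatter) lies within the scatter, while a 2.8-fold lower number from compound 1 to compound 3 (0.44 log units; beyond the scatter) and a 2.9-fold lower number from compound 2 to compound 3 (0.46 log units; beyond the scatter) are modest. Compound 4 `COc1cc(C=C2C(=O)N(c3ccc(Cl)cc3)N(c3ccc(Cl)cc3)C2=O)ccc1O` differs from compound 1 by methoxy in place of hydrogen on an aromatic carbon. Within the data shown here, none of the measured steps bears on this change: each of them swaps the group para to the core rather than adding a methoxy beside a retained hydroxy. With no guidance from the data, she expects compound 4 to show no step beyond the scatter, a 1.1-fold lower number from compound 1 to compound 4 (0.06 log units; within the scatter), and estimates a value of 30000 nM, within 12000 nM to 80000 nM.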

Compound 4, half-maximal inhibitory concentration: 7100 nM
The estimate for compound 4 lay 4.2-fold (0.63 log units) above the measured number; measured number outside the range, below it.
By their numbers in this assay, from the lowest: compounds 4 and 3 (each within the scatter of the next); then compounds 1 and 2 (each within the scatter of the next).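

Adding a methoxy ortho to a hydroxy group, a change none of the earlier steps touched, gives in this assay a 4.8-fold lower number from compound 1 to compound 4 (0.68 log units; beyond the scatter), so this ring responds to an added group and not only to a swapped one. Against the other halogen-bearing compounds the data give a 5.0-fold lower number from compound 2 to compound 4 (0.70 log units; beyond the scatter) but only a 1.7-fold lower number from compound 3 to compound 4 (0.24 log units; within the scatter), so the 4-hydroxy-3-methoxyphenyl and 4-bromophenyl groups cannot be ordered. Nothing measured here gives a reason for these steps.

From the compounds shown here alone, whether the gain depends on the retained hydroxy stays open, as does whether an ethoxy or an amine on that carbon would do the same.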